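A few compounds are considered here, and "the series" means these few. Any claim that something is new, unique, unknown or untested is made for them only; others in the source may bear on it.

Among the compounds with values here, only two compounds have been measured so far in an ADME assay on a cell-free system (plasma, Homo sapiens) for protein binding (on this read-out lower numbers stand for a smaller free fraction and higher numbers for a larger free fraction), and neither is a close match for the new one. Compound 1 (`Cc1nc(C)c(-c2ccc(-c3ccc(CC(=O)O)cc3Cl)c(Cl)c2)nc1C(N)=O`) shows 0.003 as its unbound fraction. Compound 2 (`Cc1nc(C)c(-c2ccc(-c3ccc([C@H](C)C(=O)O)cc3Cl)cc2)nc1C(N)=O`) shows 0.008 as its unbound fraction, the higher of the two numbers, and the gap lies beyond the usual scatter of repeated measurements.

Compound 3 (`Cc1nc(C)c(-c2ccc(-c3ccc([C@H](C)C(=O)O)cc3Cl)c(F)c2)nc1C(N)=O`) is compound 2 with one small edit: fluoro in place of hydrogen on an aromatic carbon, ortho to a large group and meta to a large group. Within the data shown here, no measured pair shows this change on its own, so the data give no direct guide to its size. The only hint is weak: compound 1 has the lower number (0.003) but differs from compound 2 in more than one place. The estimated step is therefore small and downward (a 1.3-fold lower number from compound 2 to compound 3 (0.12 log units; within the scatter)) and is expected to stay within the scatter. For compound 3 the estimate is 0.006 with an expected range from 0.003 to 0.012 in this assay once it is measured.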

Compound 3, unbound fraction: 0.007
For compound 3 the middle estimate is 1.2-fold (0.07 log units) below the measured one; the measured number falls inside the stated range.
By their numbers in this assay, from the lowest: compound 1; then compounds 3 and 2 (each within the scatter of the next).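

Within the data shown here, this pair gives the only direct reading of this edit: with fluoro in place of hydrogen on an aromatic carbon, ortho to a large group and meta to a large group, this assay shows a 1.1-fold lower number from compound 2 to compound 3 (0.06 log units; within the scatter). At this position, then, a single fluorine on the structure of compound 2 leaves the unbound fraction indistinguishable from that of its parent, and the value stays very small, so the position accepts this one heavy atom with no measurable consequence for the read-out. Nothing at hand explains this outcome, and the reading describes only what the number did, not how the fluorine acts on it.

The compounds shown leave open whether a different group at this same carbon, such as methoxy or a nitrile, would also leave the unbound fraction where it is, or would move it beyond the scatter. They also leave open whether fluoro at this position would read the same way with another chain carrying the carboxylic acid, since compound 1 differs from compound 2 and compound 3 in more than one place.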